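Extending the side chain of compound 3 with a guanidine-bearing group

The compounds below may be only part of what the source reports. "The series", "measured", "known", "first", "only" and "open" are said of these compounds alone.

Measured compounds:
compound 1, `C[C@@H](O)[C@H](NC(=O)CN(c1ncnc2c1ncn2C1CCCCO1)C1CC1)C(=O)OCc1ccccc1`: 23.4%
compound 2, `NC(=O)C[C@H](NC(=O)CN(c1ncnc2c1ncn2C1CCCCO1)C1CC1)C(=O)OCc1ccccc1`: 35%
compound 3, `C[C@H](NC(=O)CN(c1ncnc2c1ncn2C1CCCCO1)C1CC1)C(=O)OCc1ccccc1`: 32.1%

In a functional assay on the whole organism (Tail, strain ICR) with Mus musculus as the target, in the tail flick test, with a stated time of 90 min, at a dose of 25 umol/kg by the oral route (on this read-out higher numbers stand for a stronger effect at the one dose given and lower numbers for a weaker effect), compound 3 gives 32.1%. It stands within the scatter of both neighbours: a number 2.9 percentage points lower from compound 2 to compound 3 (within the scatter) and a number 8.7 percentage points higher from compound 1 to compound 3 (within the scatter), while a number 11.6 percentage points higher from compound 1 to compound 2 (beyond the scatter). Compound 4, `N=C(N)NCCC[C@H](NC(=O)CN(c1ncnc2c1ncn2C1CCCCO1)C1CC1)C(=O)OCc1ccccc1`, differs from compound 3 by a group of 6 heavy atoms (3 carbon, 3 nitrogen; no ring) in place of a hydrogen atom, on a saturated chain carbon, two bonds along the chain from an amide-type nitrogen and a carbonyl carbon. The step that bears on this change is the one at the same place, a number 2.9 percentage points lower from compound 2 to compound 3 (within the scatter), which stayed within the scatter; the other two steps altered the side chain as well and were modest or within the scatter. On that basis no step beyond the scatter is expected: a number 0.9 percentage points higher from compound 3 to compound 4 (within the scatter). Compound 4 is therefore estimated at 33%, with a range from 20% to 47%.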

Compound 4, a percentage reported as activity, at one dose (the size of the read-out at that dose, not a potency): 61.6%
Beside the measured number, compound 4's estimate is 28.6 percentage points below it; the measured number lies above the stated range.
By their numbers in this assay, from the lowest: compounds 1, 3 and 2 (each within the scatter of the next, the first and the last beyond it); then compound 4.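

In this assay this position turns out to tolerate a much larger side chain, and the read-out moves well beyond the scatter: the group of 6 heavy atoms in place of a hydrogen atom gives a number 29.5 percentage points higher from compound 3 to compound 4 (beyond the scatter). Compound 4 also stands clear of the other two side chains, with a number 26.6 percentage points higher from compound 2 to compound 4 (beyond the scatter) and a number 38.2 percentage points higher from compound 1 to compound 4 (beyond the scatter). Nothing available here accounts for this gain.

As far as these compounds go, whether it belongs to the guanidine end or to the chain carrying it stays open. An amine on the same chain, or a plain alkyl chain, would separate the two.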